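The source may hold more compounds than are shown below. What is called first, only, known or untested is meant among the compounds shown, and "the series" means these compounds.

The account opens with compound 1 `Cc1nc(C)c(C(=O)Nc2ccc(F)c(-c3nc4ncc(-c5cccnc5Cl)cn4n3)c2)o1`. In an ADME assay on microsomes from liver (Homo sapiens) for metabolic stability, read by LC-MS (on this read-out lower numbers stand for a shorter-lived compound and higher numbers for a longer-lived compound), compound 1 reaches only a limit of the assay, > 1.5 h. This places compound 1 at the limit of > 1.5 h in this assay, at which 1 of the 2 values shown sits. The other measured compound, compound 2 `O=C(Nc1ccc(F)c(-c2nc3ncc(-c4cc(F)cc(F)c4)cc3[nH]2)c1)N1CCCC1`, shares part of the core; in this assay compound 2 gives 0.175 h. Among the measured compounds shown here, no step between measured compounds that differ in a single place is recorded, so compound 2 offers only its own number and no comparison to compound 1 can be drawn. Compound 3 `Cc1nc(C)c(C(=O)Nc2ccc(F)c(-c3nc4ncc(-c5ccccc5Cl)cn4n3)c2)o1` has not yet been measured in this assay. It differs from compound 1 in one place: 2-chlorophenyl in place of 2-chloropyridin-3-yl on an aromatic carbon. The step is expected to stay within the scatter, estimated at a number no higher from compound 1 to compound 3 (the limit leaves the size open). In this assay compound 3 is therefore expected to give 1.5 h, with a range from 0.6 h to 4 h.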

Compound 3, half-life in the Homo sapiens assay: > 1.5 h
Compound 3: only a limit was reported; the forecaster's own chance of this, stated with the estimate: 50%; the middle value sits exactly at the limit.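

In the Homo sapiens assay compound 1 and compound 3 both reach only a limit of the assay, so no step can be read between them. In a physicochemical assay for solubility, read by LC-MS, at pH 2, tested at 50 uM (a lower number here means a less soluble compound, a higher number a more soluble compound), compound 1 gives 4080 nM and compound 3 gives 1800 nM. Going by these compounds, how far either half-life lies beyond that limit stays open.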